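Changing the fluorinated ring of compound 1

The source may report more compounds than this note shows. Statements on the series, on what has been measured and on what is new or still open speak of the compounds shown alone.

In a functional assay on U-251 cells (Homo sapiens) (on this read-out higher numbers stand for weaker inhibition of growth and lower numbers for stronger inhibition of growth), compound 1 `O=S(=O)(/C=C/c1ccc(F)cc1)Cc1ccc(Nc2ncnc3ccccc23)cc1` gives 10 nM, the lowest number of the series. Compound 2 `O=S(=O)(/C=C/c1ccc(Cl)c(Cl)c1)Cc1ccc(Nc2ncnc3ccccc23)cc1` gives 11000 nM. Compound 3 `O=S(=O)(/C=C/c1ccc(Br)cc1)Cc1ccc(Nc2ncnc3ccccc23)cc1` gives > 100000 nM, which is a limit of the assay and not a number.

Compound 4 `O=S(=O)(/C=C/c1ccc(C(F)(F)F)cc1F)Cc1ccc(Nc2ncnc3ccccc23)cc1` has not yet been measured. It keeps the shared core but carries 2-fluoro-4-(trifluoromethyl)phenyl in place of 4-fluorophenyl on a double-bonded chain carbon bound to a double-bonded chain carbon.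

Two measured steps changed the same ring, and both were large and pointed towards weaker inhibition of growth: a 1100-fold higher number from compound 1 to compound 2 (3.04 log units; beyond the scatter) and an at least 10000-fold higher number from compound 1 to compound 3 (4.00 log units; beyond the scatter). Among the compounds with values here, these are only two examples, and neither involves the new group, so the size of the next step is uncertain. Going by compound 2 and compound 3, a large rise is still expected, not a step within the scatter. The expected step is a 200-fold higher number from compound 1 to compound 4 (2.30 log units; beyond the scatter). For compound 4 the estimated value is 2000 nM, with an expected range from 50 nM to 100000 nM.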

Compound 4, concentration for 50% growth inhibition: 100000 nM
Compound 4: middle estimate off by 50-fold (1.70 log units), on the low side; low and high end bracket the measured number.
By their numbers in this assay, from the lowest: compound 1; then compound 2; then compound 4.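

In this assay, 2-fluoro-4-(trifluoromethyl)phenyl gives a 10000-fold higher number from compound 1 to compound 4 (4.00 log units; beyond the scatter), so this third replacement of 4-fluorophenyl on the double-bonded chain carbon also weakens inhibition of growth by a large step, and a ring that still carries fluorine does not keep the low number of compound 1. Measured against 3,4-dichlorophenyl, the same ring gives a 9.1-fold higher number from compound 2 to compound 4 (0.96 log units; beyond the scatter), so these replacements differ among themselves as well. The step from compound 3 to compound 4 cannot be read because compound 3 stands at a limit of the assay: the limit of > 100000 nM in this assay, at which 1 of the 4 values shown sits.

On these data alone, measured against 4-bromophenyl, the same ring gives a number no higher from compound 3 to compound 4 (the limit leaves the size open), and it remains open whether any ring other than 4-fluorophenyl can hold a number as low as that of compound 1. As far as these compounds go, how a phenyl ring carrying a methoxy group or an amine would behave at this place also stays unknown.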